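A few compounds are considered here, and "the series" means these few. Any claim that something is new, unique, unknown or untested is made for them only; others in the source may bear on it.

Measured compounds:
- compound 1, `O=C(CN1C(=O)/C(=C/c2ccc(-c3ccc(Cl)cc3)o2)SC1=S)NCc1ccc(C(F)(F)F)cc1`: in a functional assay on K562 cells (Homo sapiens) for cytotoxicity, read by MTT assay, with a stated time of 72 h (on this read-out higher numbers stand for weaker inhibition and lower numbers for stronger inhibition), compound 1 gives 155000 nM
- compound 2, `O=C(CN1C(=O)/C(=C/c2ccc(-c3ccc(Cl)cc3)o2)SC1=S)NCc1ccc(F)cc1`: compound 2 gives 150000 nM
- compound 3, `O=C(CN1C(=O)/C(=C/c2ccc(-c3ccc(Cl)cc3)o2)SC1=S)NCc1ccccc1Cl`: compound 3 gives 64000 nM

Compound 3 stands lowest of the three numbers. Its steps from the other two, a 2.4-fold lower number from compound 1 to compound 3 (0.38 log units; beyond the scatter) and a 2.3-fold lower number from compound 2 to compound 3 (0.37 log units; beyond the scatter), both lie beyond the scatter, whereas a 1.0-fold lower number from compound 1 to compound 2 (0.01 log units; within the scatter) does not.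

The next compound, compound 4, `O=C(CN1C(=O)/C(=C/c2ccc(-c3ccc(Cl)cc3)o2)SC1=S)Nc1nnn[nH]1`, differs from compound 3 by 1H-tetrazol-5-yl in place of 2-chlorobenzyl on an amide-type nitrogen. Within the data shown here, none of the measured steps bears directly on this change: all three exchange only the substituent on the benzyl ring, and the two that move the number beyond the scatter are modest, as printed with them. The change into compound 4 removes the benzyl ring altogether, so the measured steps give no direction, only a sense that changes at this position have so far shifted the number little.

The estimate for compound 4 in this assay is 100000 nM, with a wide range from 20000 nM to 400000 nM. The expected step is a 1.6-fold higher number from compound 3 to compound 4 (0.19 log units; within the scatter), with its direction uncertain.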

Compound 4, half-maximal inhibitory concentration: 52000 nM
Estimate against measurement, compound 4: 1.9-fold (0.28 log units) above, and the stated range covers the measured number.
By their numbers in this assay, from the lowest: compounds 4 and 3 (each within the scatter of the next); then compounds 2 and 1 (each within the scatter of the next).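

In this assay, the substituent on the amide-type nitrogen need not be a benzyl group to reach the lower part of the series: the exchange of 2-chlorobenzyl for 1H-tetrazol-5-yl gives a 1.2-fold lower number from compound 3 to compound 4 (0.09 log units; within the scatter) and so stays level within the scatter. The same group set against the other two benzyl amides gives a 2.9-fold lower number from compound 2 to compound 4 (0.46 log units; beyond the scatter) and a 3.0-fold lower number from compound 1 to compound 4 (0.47 log units; beyond the scatter), both modest steps of about the size already seen for the 2-chlorobenzyl group, so two very different groups now share the lower end of the series. No measurement at hand accounts for this match between a ring of carbon only and a ring with 4 hetero atoms.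

Open, on these data alone, is how a carboxylic acid, a plain amine or a phenyl group on this amide-type nitrogen would compare. Also open, as far as these compounds go, is whether any group here can move the number well beyond these modest steps.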